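A few compounds are considered here, and "the series" means these few. Any claim that something is new, unique, unknown or untested is made for them only; others in the source may bear on it.

In a functional assay on G-361 cells (Homo sapiens) for inhibition, with a stated time of 72 h (a higher number here means a weaker inhibitor, a lower number a stronger inhibitor), compound 1 `NC1CCC(Nc2nc(NCc3ccc(Br)cc3)c3ncn(C4CCCC4)c3n2)CC1` gives 1480 nM and compound 2 `NC1CCC(Nc2nc(NCc3ccc(-c4ccccc4)cc3)c3ncn(C4CCCC4)c3n2)CC1` gives 1020 nM, so compound 2 stands level with compound 1 within the scatter. Compound 3 `COc1ccccc1-c1ccc(CNc2nc(NC3CCC(N)CC3)nc3c2ncn3C2CCCC2)cc1` differs from compound 2 as follows: methoxy in place of hydrogen on an aromatic carbon. This is methoxy in place of hydrogen on an aromatic carbon, ortho to a large group. For the measured compounds named here, the only measured step, phenyl in place of bromo, is a 1.5-fold lower number from compound 1 to compound 2 (0.16 log units; within the scatter), and it bears on this change only indirectly, so no step beyond the scatter is expected in this assay. Compound 3 is estimated at 900 nM, with an expected range of 350 nM to 2400 nM. The estimate means an expected 1.1-fold lower number from compound 2 to compound 3 (0.05 log units; within the scatter).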

Compound 3, half-maximal inhibitory concentration: 545 nM
Compound 3: middle estimate off by 1.7-fold (0.22 log units), on the high side, within the range that was stated.
By their numbers in this assay, from the lowest: compounds 3, 2 and 1 (each within the scatter of the next, the first and the last beyond it).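

In this assay the change from phenyl to 2-methoxyphenyl, with methoxy ortho to a large group, gives a 1.9-fold lower number from compound 2 to compound 3 (0.27 log units; within the scatter) and so stays within the scatter. Measured against the bromo compound, 2-methoxyphenyl gives a 2.7-fold lower number from compound 1 to compound 3 (0.43 log units; beyond the scatter), a modest step and the only one in this series beyond the scatter. Nothing available explains either step.

Still open, on these data alone, is whether a hydroxy group, an amine or a carboxylic acid in place of methoxy would keep this reading. Ethoxy, a longer chain at the same place, also remains an open case.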